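The source may report more compounds than this note shows. Statements on the series, on what has been measured and on what is new or still open speak of the compounds shown alone.

Of the compounds shown here, two built on the same core have so far been measured in a functional assay on HepG2 cells (Homo sapiens) for cytotoxicity, read by MTT assay, with a stated time of 48 h; a lower number here means a stronger inhibitor, a higher number a weaker inhibitor. Compound 1 `CC(C)=CCC/C(C)=C/CC/C(C)=C/CC[C@@H]1[C@@]2(C)CC/C(=N\OCc3cn(-c4cccc(C(F)(F)F)c4)nn3)C(C)(C)[C@@H]2CC[C@@]1(C)O` gives 22700 nM in this assay. Compound 2 `CC(C)=CCC/C(C)=C/CC/C(C)=C/CC[C@@H]1[C@@]2(C)C/C(=C\c3ccc(OCc4cn(-c5ccc(F)cc5)nn4)cc3)C(=O)C(C)(C)[C@@H]2CC[C@@]1(C)O` gives 35900 nM in this assay, the higher of the two numbers, though its gap to compound 1 lies within the scatter of repeated measurements, so the two cannot be ordered against each other. Compound 3 `CC(C)=CCC/C(C)=C/CC/C(C)=C/CC[C@@H]1[C@@]2(C)C/C(=C\c3ccc(OCc4cn(-c5cccc([N+](=O)[O-])c5)nn4)cc3)C(=O)C(C)(C)[C@@H]2CC[C@@]1(C)O` has not yet been measured. It differs from compound 2 in one place: 3-nitrophenyl in place of 4-fluorophenyl on an aromatic nitrogen. Among the measured compounds shown here, no measured pair shows this particular change, so there is nothing to scale a step by. The two values in hand sit close together, and the change is confined to a single aryl group, so the expected step from compound 2 to compound 3 in this assay is a 1.2-fold lower number from compound 2 to compound 3 (0.08 log units; within the scatter), reaching no further than the scatter in either direction. Compound 3 is therefore estimated at 30000 nM in this assay, with a range from 10000 nM to 90000 nM.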

Compound 3, half-maximal inhibitory concentration: 117000 nM
For compound 3 the middle estimate is 3.9-fold (0.59 log units) below the measured one; measured number outside the range, above it.
By their numbers in this assay, from the lowest: compounds 1 and 2 (each within the scatter of the next); then compound 3.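

The aryl group on the aromatic nitrogen of the five-membered ring is not a silent position in this assay, since 3-nitrophenyl in place of 4-fluorophenyl gives a 3.3-fold higher number from compound 2 to compound 3 (0.51 log units; beyond the scatter), a modest step but one that lies beyond the scatter. The earlier compounds shown here could not show this, as their two values could not be ordered and no pair differing in one place had been available; here, a change confined to this single aryl group is seen to move the number, and it moves toward a weaker inhibitor. No measurement at hand accounts for the size or direction of this step.

The swap alters both the substituent and its printed position on the phenyl ring, so the two compounds cannot say whether the nitro group itself or its placement goes with the higher number, a question that 3-fluorophenyl or 4-nitrophenyl on the same nitrogen would address. As far as these compounds go, it also remains open how an unsubstituted phenyl, an aminophenyl or a carboxylic acid on that ring would read in this assay, and whether the step would hold on a core other than that of compound 2.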